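Ester Change on a Chlorophenyl-Bearing Core

The source may report more compounds than this note shows. Statements on the series, on what has been measured and on what is new or still open speak of the compounds shown alone.

Compound 1 `CN1CC[C@H](c2ccc(Cl)cc2)[C@@H](C(=O)OC(C)(C)C)C1` gives 318 nM in an assay on striatum with sodium-dependent dopamine transporter (Rattus norvegicus) as the target (on this read-out higher numbers stand for weaker inhibition and lower numbers for stronger inhibition), the lowest of the two numbers shown, while compound 2 `CN1CC[C@H](c2ccc(Cl)cc2)C(C(=O)Oc2ccccc2)C1` gives 906 nM in this assay, a higher number lying beyond the usual scatter. Compound 3 `CCOC(=O)C[C@H]1CN(C)CC[C@@H]1c1ccc(Cl)cc1` carries (ethoxycarbonyl)methyl in place of tert-butoxycarbonyl on a saturated ring carbon, that is, (ethoxycarbonyl)methyl in place of tert-butoxycarbonyl on a saturated ring carbon. Within the data shown here, no measured pair isolates this change, so the expectation rests on compound 1 alone. The change is expected to shift the number only modestly, a 1.6-fold higher number from compound 1 to compound 3 (0.20 log units; within the scatter), if at all beyond the scatter. Compound 3 is therefore estimated at 500 nM, within a range from 150 nM to 1800 nM.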

Compound 3, inhibition constant: 79 nM
Compound 3: the middle estimate sits 6.3-fold (0.80 log units) above what was measured; the whole stated range lies above it.
By their numbers in this assay, from the lowest: compound 3; then compound 1; then compound 2.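

In this assay, (ethoxycarbonyl)methyl in place of tert-butoxycarbonyl on this saturated ring carbon gives a 4.0-fold lower number from compound 1 to compound 3 (0.60 log units; beyond the scatter), showing that the number at this position responds to the change and that it falls rather than rises. The ester group therefore need not be attached directly to the ring carbon for the number to stay low. No measurement shown here explains the step.

The step cannot separate the change in the ester's alkyl part from the move of the ester one carbon away from the ring. As far as these compounds go, how a longer chain, a carboxylic acid or an amide would read at this position remains open.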